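Three ester chains, all without cytotoxicity; a cyclopropyl ester next

The compounds below may be only part of what the source reports. "The series", "measured", "known", "first", "only" and "open" are said of these compounds alone.

The measured compounds and their values in an ADME assay on PBMC cells (Homo sapiens) for cytotoxicity, read by MTT assay, with a stated time of 3 days; a higher number here means a weaker inhibitor, a lower number a stronger inhibitor:
compound 1 `CCCCCCCCCCCC(=O)OC[C@@H]1OC[C@H](n2cc(C)c(=O)[nH]c2=O)O1` gives > 100000 nM.
compound 2 `CCCCCCCCCCCCCCCC(=O)OC[C@@H]1OC[C@H](n2cc(C)c(=O)[nH]c2=O)O1` gives > 100000 nM.
compound 3 `CCCCCCCC(=O)OC[C@@H]1OC[C@H](n2cc(C)c(=O)[nH]c2=O)O1` gives > 100000 nM.

Each of these three values is a limit of this assay and not a number. Compound 3 therefore stands only at that limit; the same holds for compound 1 and for compound 2, so that the limit of > 100000 nM in this assay, at which 3 of the 3 values shown sit, is all the evidence there is. The step that the two limits leave unreadable from compound 1 to compound 2, the step that the two limits leave unreadable from compound 1 to compound 3 and the step that the two limits leave unreadable from compound 2 to compound 3 are all unreadable because of the limit of > 100000 nM in this assay, at which 3 of the 3 values shown sit.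

The next compound, compound 4 `Cc1cn([C@H]2CO[C@@H](COC(=O)C3CC3)O2)c(=O)[nH]c1=O`, differs from compound 3 by cyclopropyl in place of heptyl on a carbonyl carbon. Within the data shown here, none of the measured steps gives a readable size, so no change in this assay beyond the scatter can be predicted from them; the three limits together, (the limit of > 100000 nM in this assay, at which 3 of the 3 values shown sit), only suggest that shortening or lengthening the ester chain did not bring any value into the measurable range. For compound 4 the step that the limit leaves unreadable from compound 3 to compound 4 is therefore expected to be small and most likely again unreadable. Compound 4 is estimated at 150000 nM, within 50000 nM to 500000 nM, with a high chance that this assay reports only a limit for it.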

Compound 4, half-maximal inhibitory concentration: > 100000 nM
Compound 4 gave a limit, no number (the forecaster's own chance of this, stated with the estimate: 85%); the middle value lies beyond the limit too.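

In this assay compound 4 gives > 100000 nM as a limit and not a number. The step between compound 3 and compound 4 therefore cannot be read, because both stand only at a limit: the limit of > 100000 nM in this assay, at which 4 of the 4 values shown sit.
The compounds shown leave open whether any ester on the shared core reaches a measurable value in this assay and how far these esters differ.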